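Chain amide in place of a plain phenylpropyl link

A few compounds are considered here, and "the series" means these few. Any claim that something is new, unique, unknown or untested is made for them only; others in the source may bear on it.

Compound 1 `CC(C)(N)C(=O)N[C@H](COCc1ccccc1)c1nnnn1CCCc1ccccc1`: 200 nM
Compound 2 `CC(C)(N)C(=O)N[C@H](COCc1ccccc1)c1nnn(CC2Cc3ccccc3N2S(C)(=O)=O)n1`: > 5000 nM

Compound 1 carries a phenylpropyl chain on the aromatic nitrogen of the shared core, and in an assay on isolated protein for displacement of a labelled ligand from growth hormone secretagogue receptor type 1 (Homo sapiens), with a stated time of 1 h (on this read-out higher numbers stand for weaker inhibition and lower numbers for stronger inhibition), compound 1 gives 200 nM. Compound 2 carries a sulfonylated bicyclic substituent on the same nitrogen instead; in this assay compound 2 reaches only the limit of the measurement, > 5000 nM. Of the two numbers shown, compound 1 thus holds the only true value, while the other sits at the limit of > 5000 nM in this assay, at which 1 of the 2 values shown sits.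

Compound 3 `CC(C)(N)C(=O)N[C@H](COCc1ccccc1)c1nnnn1CCC(=O)NCc1ccccc1` is the compound not yet measured. It differs from compound 1 by benzylcarbamoyl in place of benzyl on a saturated chain carbon, two bonds along the chain from an aromatic nitrogen. The benzyl group on the far end of the chain is kept, but an amide now sits in the chain ahead of it, so the chain grows longer and gains a donor and an acceptor. For the measured compounds named here, no pair of measured compounds shows what such an insertion does on this assay, so the size of the step rests on the change alone. A loss within the scatter or a modest weakening is expected, a 3.0-fold higher number from compound 1 to compound 3 (0.48 log units; beyond the scatter). Compound 3 is therefore estimated at 600 nM, with a likely range from 150 nM to 3000 nM.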

Compound 3, inhibition constant: 1070 nM
Compound 3: the middle estimate sits 1.8-fold (0.25 log units) below what was measured; low and high end bracket the measured number.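

Benzylcarbamoyl in place of benzyl on a saturated chain carbon, two bonds along the chain from an aromatic nitrogen, gives the first step that can be read at this position in this assay, and it is a modest one: a 5.4-fold higher number from compound 1 to compound 3 (0.73 log units; beyond the scatter). The step lies beyond the scatter, yet compound 3 still gives a true value, so this position accepts a longer chain carrying an amide, with the phenyl ring kept at its far end, at a modest cost in this read-out. Compound 2, with its sulfonylated bicyclic substituent on the aromatic nitrogen, differs from compound 3 in more than one place and stays a limit rather than a number: the limit of > 5000 nM in this assay, at which 1 of the 3 values shown sits.

The single step joins the amide and the added length in one change, so the compounds shown do not tell which of the two accounts for the weaker number, and a plain phenylbutyl chain or an ether in the chain would be needed to separate them. Going by these compounds, how an amine or a carboxylic acid on this chain would read in this assay also remains open.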